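Bromo for Methyl on Two Related Ring Cores

The source may hold more compounds than are shown below. What is called first, only, known or untested is meant among the compounds shown, and "the series" means these compounds.

Measured in a functional assay on P388 cells (Mus musculus) for inhibition (on this read-out lower numbers stand for stronger inhibition and higher numbers for weaker inhibition), so far:
compound 1 `Cc1ccccc1/C=C1\CCc2ccccc2C1=O` gives 17700 nM
compound 2 `O=C1/C(=C/c2ccccc2Br)CCc2ccccc21` gives 19700 nM
compound 3 `Cc1ccccc1/C=C1\Cc2ccccc2C1=O` gives 23900 nM

Compound 1 and compound 2 share a core and differ only by bromo in place of methyl on an aromatic carbon. That change made a 1.1-fold higher number from compound 1 to compound 2 (0.05 log units; within the scatter). Compound 3 carries a different core; the difference between the two cores is not broken down here. Its value and those of compound 1 and compound 2 lie within the usual scatter of one another.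

Compound 4 `O=C1/C(=C/c2ccccc2Br)Cc2ccccc21` is not yet measured. It stands to compound 3 as compound 2 stands to compound 1, by the same change, (bromo in place of methyl on an aromatic carbon), with the same surroundings at the place. The step from compound 3 to compound 4 in this assay is therefore expected to be small, a 1.1-fold higher number from compound 3 to compound 4 (0.04 log units; within the scatter), because the same change gave a 1.1-fold higher number from compound 1 to compound 2 (0.05 log units; within the scatter). Compound 4 is estimated at 26000 nM, likely between 13000 nM and 52000 nM.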

Compound 4, half-maximal inhibitory concentration: > 50000 nM
Compound 4 gave a limit, no number; the forecaster's own chance of this, stated with the estimate: 5%; at least 1.9-fold (0.28 log units) between middle value and limit.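

In this assay compound 4 gives > 50000 nM, which is a limit of the assay and not a number. On the core of compound 3, bromo in place of methyl on an aromatic carbon gave an at least 2.0-fold higher number from compound 3 to compound 4 (0.32 log units; beyond the scatter), so inhibition is weaker after the change, and the true size of the step is known from one side only. This does not show that the change behaves differently on the two cores, and it does not show that it behaves alike: the same change on two cores in this assay, a 1.1-fold higher number (0.05 log units; within the scatter) from compound 1 to compound 2 and an at least 2.0-fold higher number (0.32 log units; beyond the scatter) from compound 3 to compound 4; the limit leaves it open whether they differ

The compounds shown leave open how far above the limit compound 4 really lies. They also leave open what other groups at this place, such as an amine or a carboxylic acid, would do on either core.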